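Swapping Hydroxy for Methyl: An Expected Shift

The compounds below may be only part of what the source reports. "The series", "measured", "known", "first", "only" and "open" are said of these compounds alone.

Measured compounds:
compound 1, `CS(=O)(=O)Nc1ccc(O)c2c1CCCC2c1c[nH]cn1`, 34%
compound 2, `CC(C)S(=O)(=O)Nc1cccc2c1CCCC2c1c[nH]cn1`, 74%

Both compounds were tested in a functional assay on Urethra with Alpha-1A adrenergic receptor (Oryctolagus cuniculus) as the target; on this read-out higher numbers stand for larger maximal responses and lower numbers for smaller maximal responses. Compound 1 gives 34% and stands lowest of the two numbers, while compound 2 gives 74%, a number beyond the usual scatter above compound 1. Among the measured compounds shown here, compound 2 differs from compound 1 in more than one place, so the two values show only that a compound lacking the hydroxy can reach a much larger maximal response.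

Compound 3, `Cc1ccc(NS(C)(=O)=O)c2c1C(c1c[nH]cn1)CCC2`, has not yet been measured. It differs from compound 1 by a single change: methyl in place of hydroxy on an aromatic carbon. Compound 2 reaches 74% without a hydroxy. On that basis an upward step is expected, estimated as a number 21 percentage points higher from compound 1 to compound 3 (beyond the scatter), though with considerable uncertainty. Compound 3 is therefore expected to reach about 55% in this assay, with a plausible range from 30% to 80%.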

Compound 3, largest response reached (reported as efficacy), in percent of the reference or control that the assay uses: 35%
Beside the measured number, compound 3's estimate is 20 percentage points above it; measured number inside the range.
By their numbers in this assay, from the lowest: compounds 1 and 3 (each within the scatter of the next); then compound 2.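

In this assay, putting methyl in place of hydroxy on this aromatic carbon, para to a methanesulfonamido group, gives a number 1 percentage points higher from compound 1 to compound 3 (within the scatter). At this position, then, a group counted with one hydrogen-bond donor and one acceptor and a group counted with neither give numbers that cannot be told apart on this read-out, something the earlier pair, which differed in more than one place, could not show. No measurement is available here that would explain this result.

Still open, from the compounds shown here alone, is whether this position accepts other groups equally, such as an amine, a carboxylic acid or a longer chain like propyl. Also open, going by these compounds, is what a plain hydrogen at this carbon would give on the otherwise unchanged core of compound 1.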